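A few compounds are considered here, and "the series" means these few. Any claim that something is new, unique, unknown or untested is made for them only; others in the source may bear on it.

Of the compounds shown here, three with a shared core have been measured. Compound 1 `O=C(NC1CCCCC1)c1cc2ccccc2oc1=O` gives 500 nM in an in vitro assay on BTI-TN-5B1-4 cells for inhibition of Amine oxidase [flavin-containing] B (Homo sapiens), read by fluorescence; a higher number here means a weaker inhibitor, a lower number a stronger inhibitor. Compound 2 `CC(C)CNC(=O)c1cc2ccccc2oc1=O` gives 3270 nM in this assay, and compound 3 `NCCNC(=O)c1cc2ccccc2oc1=O` gives 7680 nM, the highest number of the three. Compound 4 `O=C(Nc1ccccc1)c1cc2ccccc2oc1=O` has not yet been measured. Its change from compound 3 is phenyl in place of 2-aminoethyl on an amide-type nitrogen. Among the measured compounds shown here, the steps that bear on this are a 15-fold higher number from compound 1 to compound 3 (1.19 log units; beyond the scatter), which removed a cyclohexyl ring from that nitrogen, and a 2.3-fold higher number from compound 2 to compound 3 (0.37 log units; beyond the scatter). Going by these compounds, since a six-membered ring returns to the amide nitrogen, a lower number, back toward compound 1, is expected, though an aromatic ring is untested here. Compound 4 is therefore expected to give 700 nM, between 250 nM and 2500 nM, an expected step of an 11-fold lower number from compound 3 to compound 4 (1.04 log units; beyond the scatter).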

Compound 4, half-maximal inhibitory concentration: 760 nM
Beside the measured number, compound 4's estimate is 1.1-fold (0.04 log units) below it; the range from low to high includes it.
By their numbers in this assay, from the lowest: compounds 1 and 4 (each within the scatter of the next); then compound 2; then compound 3.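

Swapping a saturated ring for an aromatic one on the amide-type nitrogen makes no readable difference: phenyl in place of cyclohexyl gives a 1.5-fold higher number from compound 1 to compound 4 (0.18 log units; within the scatter) and so stays within the scatter. Phenyl also gives lower numbers than either open chain, with a 4.3-fold lower number from compound 2 to compound 4 (0.63 log units; beyond the scatter) and a 10-fold lower number from compound 3 to compound 4 (1.00 log units; beyond the scatter) as its steps. So a ring on this nitrogen need not be saturated, at least for these two rings. Nothing measured here explains these differences. Still open, going by these compounds, is whether a benzyl group, or a phenyl ring carrying a chlorine or a methoxy group, holds this level.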